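Anilide in place of the acid on the furan-free core

The compounds below may be only part of what the source reports. "The series", "measured", "known", "first", "only" and "open" are said of these compounds alone.

Measured so far:
Compound 1 `C=CC1=C(C(=O)NCc2ccc(C)cc2)C(c2ccc(OC)c(OC)c2)OC1`: > 100000 nM
Compound 2 `C=CC1=C(C(=O)O)C(c2ccc(OC)c(OC)c2)OC1`: 18000 nM

In a functional assay on HeLa cells (Homo sapiens) for cytotoxicity, read by MTT assay, with a stated time of 24 h (on this read-out lower numbers stand for stronger inhibition and higher numbers for weaker inhibition), compound 1 gives only a limit, > 100000 nM. In this assay compound 2 gives 18000 nM, the only number shown. Among the compounds with values here, the step of an at least 5.5-fold lower number from compound 1 to compound 2 (0.74 log units; beyond the scatter) is the one measured change at the carbonyl carbon. Compound 3 `C=CC1=C(C(=O)Nc2ccccc2)C(c2ccc(OC)c(OC)c2)OC1` carries the change (anilino in place of hydroxy on a carbonyl carbon). Reversing the earlier direction, the step of an at least 5.5-fold lower number from compound 1 to compound 2 (0.74 log units; beyond the scatter) points to a higher number for compound 3, with a real chance that it again reaches the limit (the limit of > 100000 nM in this assay, at which 1 of the 2 values shown sits). The expected step is a 4.4-fold higher number from compound 2 to compound 3 (0.65 log units; beyond the scatter). Compound 3 is therefore expected at 80000 nM, within a range from 15000 nM to 300000 nM.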

Compound 3, half-maximal inhibitory concentration: 5030 nM
Compound 3: the middle estimate sits 16-fold (1.20 log units) above what was measured; the measured number lies below the stated range.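

In this assay, an amide at this carbonyl carbon can outperform the acid, as anilino in place of hydroxy gives a 3.6-fold lower number from compound 2 to compound 3 (0.55 log units; beyond the scatter). The group on the amide-type nitrogen also matters, since phenyl in place of 4-methylbenzyl gives an at least 19-fold lower number from compound 1 to compound 3 (1.29 log units; beyond the scatter). Compound 1 remains a limit, not a number: the limit of > 100000 nM in this assay, at which 1 of the 3 values shown sits.

The compounds shown leave open whether an unsubstituted benzylamino group on this carbonyl carbon would behave like the anilino group of compound 3 or the (4-methylbenzyl)amino group of compound 1. They also leave open how a methyl ester would compare with the acid of compound 2.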